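This account rests on a few compounds, and the source may have more. Where it says the series, first, only, none or still open, it means among the compounds named here.

Measured so far:
compound 1, `CC(=O)c1cccc(NC(=O)N2CC2C#N)c1`: 3300 nM
compound 2, `N#CC1CN1C(=O)Nc1ccc([N+](=O)[O-])cc1`: 4300 nM

Both numbers come from a functional assay on WiDr cells (Homo sapiens) for inhibition; a higher number here means a weaker inhibitor, a lower number a stronger inhibitor. Compound 2 holds the highest of the two numbers, but its nearest neighbour is compound 1, and the gap between the two lies within the scatter, so no order between them can be read. Among the compounds with values here, no pair among the measured compounds differs in a single place, so there is no measured step to gauge the change toward compound 3, `N#CC1CN1C(=O)Nc1ccccc1`, which remains to be tested. Compound 3 differs from compound 2 by hydrogen in place of nitro on an aromatic carbon. Without a measured step of this kind in this assay, only a modest step is expected, a somewhat higher number for compound 3 judged slightly more likely than a lower one, though a result within the scatter of compound 2 would not surprise. The estimated step is a 1.2-fold higher number from compound 2 to compound 3 (0.07 log units; within the scatter). The expected value for compound 3 in this assay is 5000 nM, with a range from 1500 nM to 16000 nM.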

Compound 3, half-maximal inhibitory concentration: 5000 nM
The estimate for compound 3 equals the measured number at the digits printed, and the stated range covers the measured number.
By their numbers in this assay, from the lowest: compounds 1, 2 and 3 (each within the scatter of the next).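

Hydrogen in place of nitro on an aromatic carbon, para to a group of 8 heavy atoms, gives a 1.2-fold higher number from compound 2 to compound 3 (0.07 log units; within the scatter) in this assay on this series. Hydrogen in place of acetyl on an aromatic carbon gives a 1.5-fold higher number from compound 1 to compound 3 (0.18 log units; within the scatter) as its step, so in this assay neither nitro nor acetyl is shown to be needed for the inhibition seen with compound 3. No separate measurement bears on the reason for the size of these steps.

Still open, going by these compounds, is whether an amine, a carboxylic acid or a chlorine atom on the aromatic ring would give a step beyond the scatter. The compounds shown also leave open how the number responds to replacing the nitrile or altering the shared core, as all three carry these unchanged.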